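Benzyl halogen exchange in a shared core series

The source may hold more compounds than are shown below. What is called first, only, known or untested is meant among the compounds shown, and "the series" means these compounds.

Compound 1 `O=C1/C(=C/c2ccccc2F)CN(C(=S)SCc2cn(Cc3cccc(Cl)c3)nn2)C/C1=C\c1ccccc1F` is the reference point. In a functional assay on DU-145 cells (Homo sapiens) for cytotoxicity, read by MTT assay, with a stated time of 24 h (a lower number here means a stronger inhibitor, a higher number a weaker inhibitor), compound 1 gives only a limit, > 80000 nM, and not a number. On the numbers shown it therefore sits at the upper edge, as the limit of > 80000 nM in this assay, at which 1 of the 3 values shown sits, records. Two other compounds with related cores are measured. Among the compounds with values here, compound 2 `O=C1/C(=C/c2ccccc2F)CN(Cc2cn(Cc3ccccc3F)nn2)C/C1=C\c1ccccc1F` gives 10600 nM in this assay, and compound 3 `COc1ccc(/C=C2\CN(Cc3cn(Cc4ccccc4Cl)nn3)C/C(=C\c3ccc(OC)cc3)C2=O)cc1` gives 17800 nM there; no single-place step connects either of them to compound 1 or to each other, so only their bare values can be read.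

Compound 4 `O=C1/C(=C/c2ccccc2F)CN(C(=S)SCc2cn(Cc3ccccc3F)nn2)C/C1=C\c1ccccc1F` is not yet measured. It differs from compound 1 in one place: 2-fluorophenyl in place of 3-chlorophenyl on a saturated chain carbon bound to an aromatic nitrogen. Within the data shown here, no measured pair isolates this exchange, so the size of the step cannot be taken from the data. A step within the usual scatter is expected, with the limit on compound 1 leaving room only for movement toward measurable values. The expected step is an at least 1.3-fold lower number from compound 1 to compound 4 (0.12 log units; that floor lies within the scatter). Compound 4 is estimated at 60000 nM, within 20000 nM to 150000 nM, with a fair chance that this assay again returns only a limit.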

Compound 4, half-maximal inhibitory concentration: > 80000 nM
Compound 4: no number, only a limit; the forecaster's own chance of this, stated with the estimate: 50%; middle value at least 1.3-fold (0.12 log units) from the limit.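

In this assay compound 4 gives only a limit, > 80000 nM, and not a number. Compound 1 also stands at a limit, so no step can be read between compound 1 and compound 4. The compounds shown leave open whether 2-fluorophenyl in place of 3-chlorophenyl changes the read-out at all.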